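The source may report more compounds than this note shows. Statements on the series, on what has been measured and on what is new or still open speak of the compounds shown alone.

Measured compounds:
compound 1 `Nc1nc(O)c2c(n1)n(C1OC(CO)[C@@H](O)[C@H]1O)c(=O)n2CC(O)CO`: 45 uM
compound 2 `C=CCn1c(=O)n(C2CCC(CO)C2)c2nc(N)nc(O)c21`: 226 uM
compound 3 `C=CCn1c(=O)n(CCCCCCCC)c2nc(N)nc(O)c21`: 37 uM

In a functional assay (B cells) with Mus musculus as the target (on this read-out higher numbers stand for an effect only at larger amounts of compound and lower numbers for an effect already at smaller amounts), compound 1 gives 45 uM, the second highest of the three numbers. Its nearest neighbour is compound 3, whose 37 uM lies within the scatter of compound 1; its furthest is compound 2, whose 226 uM lies beyond it. Compound 4 `N#Cc1cccc(Cn2c(=O)n(C3OC(CO)[C@@H](O)[C@H]3O)c3nc(N)nc(O)c32)c1` has not yet been measured. It differs from compound 1 in one place: 3-cyanophenyl in place of 1,2-dihydroxyethyl on a saturated chain carbon bound to an aromatic nitrogen. Going by the values given here, no measured pair shows this change, so its size is not known from the data. A modest step toward a lower number is expected, a 1.8-fold lower number from compound 1 to compound 4 (0.26 log units; within the scatter), which may still fall within the scatter. Compound 4 is estimated at 25 uM, with a range from 6 uM to 100 uM.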

Compound 4, concentration for half-maximal effect: 3 uM
Estimate against measurement, compound 4: 8.3-fold (0.92 log units) above, and the stated range ends above it.
By their numbers in this assay, from the lowest: compound 4; then compounds 3 and 1 (each within the scatter of the next); then compound 2.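

Placing 3-cyanophenyl in place of 1,2-dihydroxyethyl on a saturated chain carbon bound to an aromatic nitrogen gives a 15-fold lower number from compound 1 to compound 4 (1.18 log units; beyond the scatter) in this assay and shows that the read-out responds strongly to the group at this position, which the earlier compounds, with no pair differing in one place, could not show. The change removes both hydrogen-bond donors of the leaving group and brings in a six-membered aromatic ring. Nothing at hand accounts for the size of this step. The compounds shown leave open whether the step belongs to the aromatic ring or to the nitrile, and how a plain benzyl or a carboxylic acid on that ring would read.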